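Methoxy for hydroxy on a piperidine amide

A few compounds are considered here, and "the series" means these few. Any claim that something is new, unique, unknown or untested is made for them only; others in the source may bear on it.

The two measured compounds, with their values in a functional assay on MIA PaCa-2 cells (Homo sapiens) for inhibition, read by MTT assay, with a stated time of 3 days; on this read-out lower numbers stand for stronger inhibition and higher numbers for weaker inhibition:
Compound 1, `CCN(CC)S(=O)(=O)c1ccc(S(=O)(=O)N2CCC[C@@H](C(=O)N[C@H]3CC[C@H](OC)CC3)C2)cc1`, gives > 10000 nM.
Compound 2, `CCN(CC)S(=O)(=O)c1ccc(S(=O)(=O)N2CCC[C@@H](C(=O)N3CCC(O)CC3)C2)cc1`, gives > 10000 nM.

Compound 2 stands at a limit of this assay, not at a number. Compound 1 likewise sits at a limit. The step that the two limits leave unreadable from compound 1 to compound 2 therefore cannot be read; both values sit at the limit of > 10000 nM in this assay, at which 2 of the 2 values shown sit.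

Compound 3, `CCN(CC)S(=O)(=O)c1ccc(S(=O)(=O)N2CCC[C@@H](C(=O)N3CCC(OC)CC3)C2)cc1`, differs from compound 2 by methyl in place of hydrogen on an oxygen on a saturated carbon. For the measured compounds named here, the only measured step, the one from compound 1 to compound 2, gives no readable size, so no measured step tells how large this change should be. Because the limit of > 10000 nM in this assay, at which 2 of the 2 values shown sit, holds for every value shown, compound 3 is expected to stay in the same region: the step that the limit leaves unreadable from compound 2 to compound 3 is expected to be none beyond the scatter. Compound 3 is thus estimated at 15000 nM, within a range from 5000 nM to 60000 nM.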

Compound 3, half-maximal inhibitory concentration: > 10000 nM
Compound 3: a limit, no number (the forecaster's own chance of this, stated with the estimate: 80%); the middle value is on the limit's open side.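

Compound 3 gives > 10000 nM in this assay, which is a limit and not a number. For the compounds shown here, no step among compound 1, compound 2 and compound 3 can be read, because all three stand at the same limit: the limit of > 10000 nM in this assay, at which 3 of the 3 values shown sit. As far as these compounds go, the true strength of each compound, and so the size of each change between them, stays open.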